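Removing ring fluorines from compound 1: expectation for compound 4

This account rests on a few compounds, and the source may have more. Where it says the series, first, only, none or still open, it means among the compounds named here.

Compound 1 `O=C(COc1ccc(C(=O)/C=C/c2ccc(F)c(F)c2)cc1)N[C@H]1CCOC1=O` is one of three compounds assessed in a functional assay on MGC-803 cells (Homo sapiens) for antiproliferative activity, read by MTT assay, with a stated time of 72 h; on this read-out higher numbers stand for weaker inhibition and lower numbers for stronger inhibition. In this assay compound 1 gives > 64000 nM, which is a limit of the assay rather than a number. Compound 2 `O=C1OCC[C@@H]1NC(=S)SCCOc1cccc2ccccc12` likewise returns only a limit, > 64000 nM. Within the data shown here, compound 3 `C=CCc1ccc(OCCSC(=S)N[C@H]2CCOC2=O)c(OC)c1` is the sole member with a number, 27900 nM. Two of the three results thus sit together, (the limit of > 64000 nM in this assay, at which 2 of the 3 values shown sit). Compound 4 `O=C(COc1ccc(C(=O)/C=C/c2ccccc2)cc1)N[C@H]1CCOC1=O` differs from compound 1 by phenyl in place of 3,4-difluorophenyl on a double-bonded chain carbon bound to a double-bonded chain carbon. Among the measured compounds shown here, no measured step between two compounds differing in one place exists to gauge this change. Because compound 1 sits at the limit > 64000 nM, the expected step is a step that the limit leaves unreadable from compound 1 to compound 4, none beyond the scatter. Compound 4 is estimated at 80000 nM, within 20000 nM to 300000 nM, most likely again reported as a limit.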

Compound 4, half-maximal inhibitory concentration: > 64000 nM
Compound 4 gave a limit, no number; the forecaster's own chance of this, stated with the estimate: 80%; the middle value does not contradict the limit.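

Among these compounds, compound 1 and compound 4 both return limits in this assay, not numbers, so no step between them can be read: the limit of > 64000 nM in this assay, at which 3 of the 4 values shown sit. The compounds shown leave open whether phenyl in place of 3,4-difluorophenyl changes antiproliferative activity at all.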